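The source may report more compounds than this note shows. Statements on the series, on what has been measured and on what is new or still open speak of the compounds shown alone.

In a functional assay on HepG2 cells (Homo sapiens) for antiproliferative activity, read by MTT assay, with a stated time of 72 h (a higher number here means a weaker inhibitor, a lower number a stronger inhibitor), the measured compounds stand as follows.

Compound 1 `COc1ncc(-c2ccc3c(c2)N(C2CCCCC2)C(=O)CO3)cc1NS(=O)(=O)c1ccc(F)cc1` gives only a limit, > 40000 nM.
Compound 2 `COc1ccc(N2C(=O)COc3ccc(-c4cnc(OC)c(NS(=O)(=O)c5ccc(F)cc5)c4)cc32)cc1` gives 13100 nM.
Compound 3 `COc1ccc(N2C(=O)COc3ccc(-c4cccc(NS(=O)(=O)c5ccc(F)cc5)c4)cc32)cc1` gives 29800 nM.

Compound 3 holds the highest of the two numbers reported; compound 2 is the nearest to it, and the gap between them is beyond the scatter. The difference between the core of compound 3 and the core of compound 2 is not broken down here.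

The step from compound 2 to compound 1 is one counted change, (cyclohexyl in place of 4-methoxyphenyl on an amide-type nitrogen in a ring), and it gave an at least 3.0-fold higher number from compound 2 to compound 1 (0.48 log units; beyond the scatter). Its true size is bounded only from below, since compound 1 sits at the limit of > 40000 nM in this assay, at which 1 of the 3 values shown sits.

Compound 4 `O=C1COc2ccc(-c3cccc(NS(=O)(=O)c4ccc(F)cc4)c3)cc2N1C1CCCCC1` has not yet been measured in this assay. Among the measured compounds shown here, it differs from compound 3 by cyclohexyl in place of 4-methoxyphenyl on an amide-type nitrogen in a ring, the same change as the one from compound 2 to compound 1, made at the same place. If the change acts in compound 3 as it did in compound 2, the number for compound 4 should move upward, starting from the already high value of compound 3. The expected step is therefore a 3.0-fold higher number from compound 3 to compound 4 (0.48 log units; beyond the scatter), and this rests on the measured step of an at least 3.0-fold higher number from compound 2 to compound 1 (0.48 log units; beyond the scatter). For compound 4 an estimate of about 90000 nM is expected, most likely reported as a limit rather than as a number, with a plausible range from 35000 nM to 300000 nM.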

Compound 4, half-maximal inhibitory concentration: 35900 nM
The estimate for compound 4 lay 2.5-fold (0.40 log units) above the measured number; the measured number falls inside the stated range.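

In this assay, cyclohexyl in place of 4-methoxyphenyl on the amide-type nitrogen gives a 1.2-fold higher number from compound 3 to compound 4 (0.08 log units; within the scatter), so on this core no effect of the change can be read. This does not show that the change carries over from one core to the other in the size seen earlier, and it does not show that the two cores respond differently, as the comparison of the two steps stays unresolved: the same change on two cores in this assay, an at least 3.0-fold higher number (0.48 log units; beyond the scatter) from compound 2 to compound 1 and a 1.2-fold higher number (0.08 log units; within the scatter) from compound 3 to compound 4; the limit leaves it open whether they differ The value of compound 1, > 40000 nM, is a limit and not a number, and it is the only such value in this small set: the limit of > 40000 nM in this assay, at which 1 of the 4 values shown sits.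

Among the compounds shown here, with only two pairs, one of them bounded on one side, the series offers no general rule for this change, and what holds on any further core remains open. Also open, from the compounds shown here alone, is whether a different group on the amide-type nitrogen, such as an n-butyl chain, a benzyl group or a chain ending in a carboxylic acid or an amine, would give a number clearly apart from those of compound 3 and compound 4 in this assay.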